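A few compounds are considered here, and "the series" means these few. Any claim that something is new, unique, unknown or untested is made for them only; others in the source may bear on it.

Compound 1 `Cc1ccc2cc(C(C)N(Cc3ccc(F)cc3)Cc3ccc(C(C)C)cc3)c(=O)[nH]c2c1`: > 33000 nM
Compound 2 `Cc1ccc2[nH]c(=O)c(CN(Cc3ccc(OCC(=O)OC(C)(C)C)cc3)Cc3ccc(C(C)(C)C)cc3)cc2c1`: > 10000 nM

Of the compounds shown here, two have been tested in a toxicity assay on MDCK cells (Canis lupus familiaris) for cytotoxicity, read by crystal violet staining, with a stated time of 48 h; on this read-out higher numbers stand for lower toxicity in this test and lower numbers for higher toxicity in this test. Compound 1 gives > 33000 nM, which is a limit of the test rather than a number. Compound 2 gives > 10000 nM, again a limit and not a number. Compound 2 thus stands at the limit of > 10000 nM in this assay, at which 1 of the 2 values shown sits, while the other value shown sits at the limit of > 33000 nM in this assay, at which 1 of the 2 values shown sits; neither says how the two compare. Compound 3 `Cc1ccc2[nH]c(=O)c(CN(Cc3ccc(OCCO)cc3)Cc3ccc(C(C)(C)C)cc3)cc2c1` has not been measured. It differs from compound 2 in one place: hydroxymethyl in place of tert-butoxycarbonyl on a saturated chain carbon bound to an oxygen on an aromatic ring. Going by the values given here, no step between measured compounds is available, so there is no direct guide to the size of this change in this assay. Among the compounds with values here, the step is expected to be a step that the limit leaves unreadable from compound 2 to compound 3, none beyond the scatter, because both compounds so far sit at the limit of > 10000 nM in this assay, at which 1 of the 2 values shown sits, or (the limit of > 33000 nM in this assay, at which 1 of the 2 values shown sits). Compound 3 is therefore estimated at 20000 nM, within 5000 nM to 100000 nM, most likely reported again only as a limit.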

Compound 3, half-maximal cytotoxic concentration: > 5000 nM
Compound 3: no number, only a limit (the forecaster's own chance of this, stated with the estimate: 70%); the middle value lies beyond the limit too.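

In this assay compound 3 gives > 5000 nM, which is a limit and not a number. Compound 2 gives > 10000 nM, also a limit, so no step can be read from compound 2 to compound 3. The compounds shown leave open at what concentration any of them becomes toxic to these cells.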